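The source may report more compounds than this note shows. Statements on the series, on what has been measured and on what is new or still open speak of the compounds shown alone.

Two pyrazoline amides have been tested in a functional assay on HepG2 cells (Homo sapiens) for cytotoxicity, read by MTT assay, with a stated time of 48 h; a lower number here means a stronger inhibitor, a higher number a weaker inhibitor. Compound 1 `CCC(=O)N1N=C(C)CC1c1cc(Br)ccc1O` has a propanoyl group on the ring nitrogen and a bromohydroxyphenyl substituent, and in this assay compound 1 is recorded as "not active" (no number reported), with no number given. Within the data shown here, compound 2 `Cc1ccc(C(=O)N2N=C(c3cc4ccccc4oc3=O)CC2c2ccccc2)cc1` carries a (4-methylphenyl)carbonyl group on the same nitrogen together with a chromenone substituent and a phenyl ring, and in this assay compound 2 gives 52300 nM, which is the only number reported in the set, so compound 2 stands as the single reference point and is a weak inhibitor.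

Compound 3 `CCCNCC(=O)N1N=C(c2cc3ccccc3oc2=O)CC1c1ccccc1` keeps the core of compound 2 and differs in one place: (propylamino)methyl in place of 4-methylphenyl on a carbonyl carbon. Among the measured compounds shown here, no measured pair shows what this kind of change does in this assay, so the expectation rests on compound 2 alone. Compound 3 is expected to remain a weak inhibitor, with a step of a 1.2-fold higher number from compound 2 to compound 3 (0.09 log units; within the scatter) that lies within the scatter or slightly toward weaker activity, because the starting point of compound 2 is 52300 nM. The estimate for compound 3 is 65000 nM, with a range from 20000 nM to 200000 nM.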

Compound 3, half-maximal inhibitory concentration: 10800 nM
For compound 3 the middle estimate is 6.0-fold (0.78 log units) above the measured one; the whole stated range lies above it.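

In this assay the substituent on a carbonyl carbon whose other neighbour is the amide-type nitrogen in a ring proves able to shift the read-out: (propylamino)methyl in place of 4-methylphenyl gives a 4.8-fold lower number from compound 2 to compound 3 (0.69 log units; beyond the scatter) in this pair, a modest step beyond the scatter. Among these compounds, this is the first comparison in the set, as compound 1 has no number and differs from the others in more than one place. It also shows that the six-membered aromatic ring of 4-methylphenyl is not required at this position for activity at this level, since compound 3 has no ring there.

The change swaps the ring for a chain and brings in a nitrogen at once, so the pair cannot separate the two, and a plain alkyl chain without nitrogen, a longer amine chain or a carboxylic acid at this position would each bear on that question. No independent measurement accounts for the step, which therefore stays unexplained.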